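The source may report more compounds than this note shows. Statements on the series, on what has been measured and on what is new or still open speak of the compounds shown alone.

Compound 1 `CNC(=O)c1cc(C(=O)N[C@H]2CC[C@H](O)CC2)n([C@@H](C)c2ccc(Cl)cc2)n1`: in a physicochemical assay for solubility, measured as kinetic solubility (a lower number here means a less soluble compound, a higher number a more soluble compound), compound 1 is recorded only at the limit >= 132 ug/mL.
Compound 2 `CC[C@@H](c1ccccc1)n1nc(C(=O)NC)cc1C(=O)N[C@H]1CC[C@H](O)CC1`: in this assay compound 2 gives 138 ug/mL.
Compound 3 `CNC(=O)c1cc(C(=O)N[C@H]2CC[C@H](O)CC2)n([C@@H](C)c2cccc(C)c2)n1`: in this assay compound 3 is recorded only at the limit >= 180 ug/mL.

Compound 3 therefore stands at a limit rather than at a number, and the same holds for compound 1 the limit of >= 132 ug/mL in this assay, at which 1 of the 3 values shown sits (the limit of >= 180 ug/mL in this assay, at which 1 of the 3 values shown sits). The step that the two limits leave unreadable from compound 1 to compound 3 cannot be read for that reason, while the step of an at least 1.3-fold higher number from compound 2 to compound 3 (0.11 log units; that floor lies within the scatter) is known only as a floor that lies within the scatter. Compound 4 `CNC(=O)c1cc(C(=O)N[C@H]2CC[C@H](O)CC2)n([C@@H](C)c2ccccc2Cl)n1` differs from compound 3 by 2-chlorophenyl in place of 3-methylphenyl on a saturated chain carbon bound to an aromatic nitrogen and a saturated chain carbon. Going by the values given here, the one measured step that bears on this exchange of one aromatic ring for another at the same place is a step that the two limits leave unreadable from compound 1 to compound 3, and it gives no size. All three measured compounds sit at or near the same high region, so the step of an at least 1.2-fold lower number from compound 3 to compound 4 (0.07 log units; that floor lies within the scatter) is expected to be none beyond the scatter, with a fair chance that only a limit is reported again. Compound 4 is thus estimated at 150 ug/mL, with a range from 60 ug/mL to 260 ug/mL.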

Compound 4, solubility: >= 182 ug/mL
Compound 4: a limit, no number; the forecaster's own chance of this, stated with the estimate: 50%; middle value at least 1.2-fold (0.08 log units) away from the limit.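

In this assay compound 4 is recorded only at a limit, >= 182 ug/mL. This makes 2-chlorophenyl the third aromatic ring, after 4-chlorophenyl and 3-methylphenyl, to give a limit at this place on the saturated chain carbon, while compound 2, with 1-phenylpropyl on the aromatic nitrogen, gives a number. Going by these compounds alone, the steps from compound 3 and from compound 1 to compound 4 cannot be read, and the only step with any size is an at least 1.3-fold higher number from compound 2 to compound 4 (0.12 log units; that floor lies within the scatter).

The numbers behind the limits of compound 1, compound 3 and compound 4 remain open, and with them any order among these three aromatic rings. Also open, as far as these compounds go, is what an amine or a carboxylic acid carried at this place would give in this assay.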